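The compounds below may be only part of what the source reports. "The series", "measured", "known", "first", "only" and "open" are said of these compounds alone.

Series notes. Compound 1 `CCCCCCCCCC(CCO)n1cnc2c(NC)ncnc21` gives 4450 nM in a functional assay on SW480 cells (Homo sapiens) for antiproliferative activity, read by MTT assay, with a stated time of 48 h; on this read-out lower numbers stand for stronger inhibition and higher numbers for weaker inhibition. Compound 2 `CCCCCCCCCC(CCO)n1cnc2c(N(C)C)ncnc21` carries methyl in place of hydrogen on a nitrogen on an aromatic ring and, in this assay, compound 2 gives 12200 nM; the step is a 2.7-fold higher number from compound 1 to compound 2 (0.44 log units; beyond the scatter). Compound 3 `CCCCCCCCCCCC(CCO)n1cnc2c(NC)ncnc21` differs from compound 1 in its core by ethyl in place of hydrogen on a saturated chain carbon, ten or more bonds along the chain from an aromatic nitrogen, and in this assay compound 3 gives 12800 nM; that step is a 2.9-fold higher number from compound 1 to compound 3 (0.46 log units; beyond the scatter). Compound 2 and compound 3 lie within the scatter of each other. Compound 4 `CCCCCCCCCCCC(CCO)n1cnc2c(N(C)C)ncnc21` is not yet measured; it differs from compound 3 by methyl in place of hydrogen on a nitrogen on an aromatic ring, the same change as that made from compound 1 to compound 2, occurring twice among these compounds. For compound 4 a step of a 2.3-fold higher number from compound 3 to compound 4 (0.37 log units; beyond the scatter) is expected in this assay because the same change gave a 2.7-fold higher number from compound 1 to compound 2 (0.44 log units; beyond the scatter) on the other core. Compound 4 is therefore estimated at 30000 nM, with a likely range from 12000 nM to 75000 nM.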

Compound 4, half-maximal inhibitory concentration: 11800 nM
Compound 4: middle estimate off by 2.5-fold (0.41 log units), on the high side; measured number outside the range, below it.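

On the core of compound 3, the methylamino to dimethylamino change gives a 1.1-fold lower number from compound 3 to compound 4 (0.04 log units; within the scatter) in this assay, so its step on the core of compound 1 does not carry over: the same change on two cores in this assay, a 2.7-fold higher number (0.44 log units; beyond the scatter) from compound 1 to compound 2 and a 1.1-fold lower number (0.04 log units; within the scatter) from compound 3 to compound 4, 3.0-fold (0.47 log units) apart, beyond the scatter of two such steps

The ethyl change likewise gives a 1.0-fold lower number from compound 2 to compound 4 (0.01 log units; within the scatter), which does not match its step on the core of compound 1: the same change on two cores in this assay, a 2.9-fold higher number (0.46 log units; beyond the scatter) from compound 1 to compound 3 and a 1.0-fold lower number (0.01 log units; within the scatter) from compound 2 to compound 4, 3.0-fold (0.47 log units) apart, beyond the scatter of two such steps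

These two comparisons rest on the same four compounds, so they show that the two changes do not add up here, but not why, nor how either change behaves on any other core.

Still open, as far as these compounds go, is how a longer chain would read in this assay. The same holds for a free amino group or a cyclic amine in place of methylamino, or a carboxylic acid in place of the alcohol.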